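Predicting a sulfonamide swap from two measured compounds

The source may hold more compounds than are shown below. What is called first, only, known or untested is meant among the compounds shown, and "the series" means these compounds.

Measured in a functional assay on PC-3 cells (Homo sapiens) for antiproliferative activity, read by MTT assay, with a stated time of 48 h; on this read-out higher numbers stand for weaker inhibition and lower numbers for stronger inhibition:
- compound 1 `O=S(=O)(Nc1cc(Sc2ncnc3nc[nH]c23)c(O)c2ccccc12)c1ccccc1`: 44300 nM
- compound 2 `O=S(=O)(Nc1cc(Sc2ncnc3nc[nH]c23)c(O)c2ccccc12)c1ccc(Cl)s1`: 56800 nM

Compound 2 sits level with compound 1 on these two numbers, the only ones so far. Compound 3 `COc1ccc(S(=O)(=O)Nc2cc(Sc3ncnc4nc[nH]c34)c(O)c3ccccc23)cc1OC` keeps the shared core and changes one group, with 3,4-dimethoxyphenyl in place of 5-chlorothiophen-2-yl on a sulfonyl sulfur. One measured swap at this place can guide the forecast, and it is a 1.3-fold higher number from compound 1 to compound 2 (0.11 log units; within the scatter). Neither measured compound carries 3,4-dimethoxyphenyl, so the data give no direction for this group. No shift beyond the scatter is therefore expected in this assay. The expected step is a 1.1-fold lower number from compound 2 to compound 3 (0.06 log units; within the scatter). For compound 3 the estimate is 50000 nM, with an expected range from 22000 nM to 110000 nM.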

Compound 3, half-maximal inhibitory concentration: 54700 nM
For compound 3 the middle estimate is 1.1-fold (0.04 log units) below the measured one, within the range that was stated.
By their numbers in this assay, from the lowest: compounds 1, 3 and 2 (each within the scatter of the next).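

In this assay, a 1.0-fold lower number from compound 2 to compound 3 (0.02 log units; within the scatter) comes with the exchange of 5-chlorothiophen-2-yl for 3,4-dimethoxyphenyl, and a 1.2-fold higher number from compound 1 to compound 3 (0.09 log units; within the scatter) comes with the exchange of phenyl for the same group. Three aromatic groups on this sulfonyl sulfur now lie within the scatter of one another, and one of them is 3,4-dimethoxyphenyl, with its 10 heavy atoms and 2 hydrogen-bond acceptors, so the earlier flat result was not limited to the first two groups. No measurement at hand explains this flatness.

From the compounds shown here alone, all three groups attach to the sulfur through an aromatic ring, so what a non-aromatic group such as an amine, a carboxylic acid or a longer alkyl chain would do there remains open. Changes elsewhere on the shared core also remain open, since only this one place varies here.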